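Propoxy to Methyl on the Shared Core of Compound 2

This account rests on a few compounds, and the source may have more. Where it says the series, first, only, none or still open, it means among the compounds named here.

Of the compounds shown here, three built on one fused core have been tested in a functional assay on aorta (Rattus norvegicus, strain Sprague-Dawley) for inhibition; a higher number here means that more compound is needed for the effect, a lower number that less compound is needed. Compound 1 `CC1COC2(C)Oc3c(c4c(c5c3CC3C(C)COC3(C)O5)CC3C(C)COC3(C)O4)CC12` gives 11000 nM in this assay. Compound 2 `CCCOc1cc2c(c3c1C[C@@H]1[C@@H](C)CO[C@]1(C)O3)C[C@@H]1[C@@H](C)CO[C@]1(C)O2` gives 77000 nM, the highest of the three numbers. Compound 3 `CC1COC2(C)Oc3cc(O)c4c(c3CC12)OC1(C)OCC(C)C1C4` gives 41000 nM, which stands within the scatter of the number for compound 2, so the two cannot be ordered. Compound 1 stands well apart from compound 2, its number being lower by an amount beyond the scatter.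

Compound 4 `Cc1cc2c(c3c1C[C@@H]1[C@@H](C)CO[C@]1(C)O3)C[C@@H]1[C@@H](C)CO[C@]1(C)O2` has not yet been measured in this assay. It differs from compound 2 at one place: methyl in place of propoxy on an aromatic carbon. Among the measured compounds shown here, no measured pair among the three compounds shows this change on its own, so its effect cannot be read from a known step.

Because the numbers for compound 2, at 77000 nM, and compound 3, at 41000 nM, fall close together with different groups at that place, compound 4 is expected to land in the same region. The step of a 1.5-fold lower number from compound 2 to compound 4 (0.19 log units; within the scatter) is estimated to be small, if anything a slight lowering, and not clearly beyond the scatter. Compound 4 is therefore estimated at 50000 nM in this assay, within a range from 15000 nM to 160000 nM.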

Compound 4, half-maximal effective concentration: 52000 nM
Beside the measured number, compound 4's estimate is 1.0-fold (0.02 log units) below it; measured number inside the range.
By their numbers in this assay, from the lowest: compound 1; then compounds 3, 4 and 2 (each within the scatter of the next).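

Among the compounds shown here, the step at this aromatic carbon, a 1.5-fold lower number from compound 2 to compound 4 (0.17 log units; within the scatter) in this assay, is the first reading of a single change at this place, and it does not show that the change alters the number. Propoxy, with 4 heavy atoms and 1 hydrogen-bond acceptor, gives way to methyl, with 1 heavy atom and 0 hydrogen-bond acceptors, so this large difference in the counted atoms comes with a step that stays inside the usual scatter for this kind of measurement. For these two groups at this place, then, the choice between the shorter and the longer substituent makes no difference that can be told apart from repeated measurement, and no measured property on hand accounts for that result.

The compounds shown leave open whether a group of a different kind at this aromatic carbon, such as an amine, a carboxylic acid or a chain longer than propoxy, would give a step beyond the scatter. They also leave open whether methyl in place of propoxy would give a similarly small step at any other aromatic carbon of the shared core.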